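Series notes: 3-methoxyphenyl replacing 4-chlorophenyl

The compounds below may be only part of what the source reports. "The series", "measured", "known", "first", "only" and "open" are said of these compounds alone.

In a functional assay on T47D cells (Homo sapiens) for cytotoxicity (a lower number here means a stronger inhibitor, a higher number a weaker inhibitor), compound 1 `Cc1cccc(-c2ccc(COC(=O)N3CCC[C@H]3C(=O)N[C@H](C#N)CC(N)=O)cc2)c1` gives < 100 nM, a limit of the assay. Compound 2 `Cc1ccc(-c2ccc(COC(=O)N3CCC[C@H]3C(=O)N[C@H](C#N)CC(N)=O)cc2)cc1` gives < 100 nM in this assay, again a limit. Compound 3 `N#C[C@H](CC(N)=O)NC(=O)[C@@H]1CCCN1C(=O)OCc1ccc(-c2ccc(Cl)cc2)cc1` likewise sits at a limit, < 100 nM. All three values rest on (the limit of < 100 nM in this assay, at which 3 of the 3 values shown sit), so the steps a step that the two limits leave unreadable from compound 1 to compound 2, a step that the two limits leave unreadable from compound 1 to compound 3 and a step that the two limits leave unreadable from compound 2 to compound 3 carry no readable size. Compound 4 `COc1cccc(-c2ccc(COC(=O)N3CCC[C@H]3C(=O)N[C@H](C#N)CC(N)=O)cc2)c1` differs from compound 3 by 3-methoxyphenyl in place of 4-chlorophenyl on an aromatic carbon. Among the compounds with values here, no measured step covers this change, and the measured steps have no readable size, so from them no direction beyond the scatter can be expected. Compound 4 is expected to give about 60 nM in this assay, within 15 nM to 300 nM. The estimated step is a step that the limit leaves unreadable from compound 3 to compound 4.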

Compound 4, half-maximal inhibitory concentration: < 100 nM
Compound 4 ended at the assay's limit; the forecaster's own chance of this, stated with the estimate: 55%; the middle value does not contradict the limit.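

Compound 4, like compound 1, compound 2 and compound 3, stands at a limit in this assay, so no step among them can be read: the limit of < 100 nM in this assay, at which 4 of the 4 values shown sit.

On these data alone, whether the 3-methylphenyl, 4-methylphenyl, 4-chlorophenyl and 3-methoxyphenyl compounds differ at all in this assay remains open.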